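The compounds below may be only part of what the source reports. "The series", "measured", "known", "first", "only" and "open" are said of these compounds alone.

Series notes. Compound 1 `Cc1[nH]n(-c2nc3cc(-c4ccccc4)ccc3[nH]2)c(=O)c1Cc1ccccc1`, compound 2 `Cc1[nH]n(-c2nc3cc(Cl)ccc3[nH]2)c(=O)c1Cc1ccccc1` and compound 3 `Cc1[nH]n(-c2nc3ccccc3[nH]2)c(=O)c1Cc1ccc(-c2ccccc2)cc1` have been measured in an assay on isolated protein for inhibition of alpha-ketoglutarate-dependent dioxygenase alkB homolog 3 (Homo sapiens), read by polymerase chain reaction, with a stated time of 1 h; on this read-out higher numbers stand for weaker inhibition and lower numbers for stronger inhibition. Compound 1 gives 810 nM, compound 2 gives 4500 nM, and compound 3 gives 720 nM. Compound 1 and compound 3 have the same atoms joined differently; the difference between the two cores is not broken down here, and their values fall within the usual scatter of each other. The counted change from compound 1 to compound 2 is chloro in place of phenyl on an aromatic carbon, which gave a 5.6-fold higher number from compound 1 to compound 2 (0.74 log units; beyond the scatter).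

Compound 4 `Cc1[nH]n(-c2nc3ccccc3[nH]2)c(=O)c1Cc1ccc(Cl)cc1` is not yet measured. It differs from compound 3 by chloro in place of phenyl on an aromatic carbon. This is the same kind of change as that from compound 1 to compound 2, but not the same: there the position is part of a fused or bridged system of two rings, meta to a fused ring and para to a fused ring, whereas in compound 4 it is para to a large group. Within the data shown here, only one earlier instance exists. Among the measured compounds shown here, compound 4 is expected to show a step of about a 5.0-fold higher number from compound 3 to compound 4 (0.70 log units; beyond the scatter) in this assay, similar in size to the earlier one because a 5.6-fold higher number from compound 1 to compound 2 (0.74 log units; beyond the scatter) is the sole precedent. Compound 4 is therefore estimated at 3600 nM, within 1500 nM to 9000 nM.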

Compound 4, half-maximal inhibitory concentration: > 10000 nM
Compound 4 gave a limit, no number; the forecaster's own chance of this, stated with the estimate: 3%; middle value at least 2.7-fold (0.44 log units) away from the limit.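

Compound 4 gives > 10000 nM in this assay, and this is a limit of the assay, not a number. Chloro in place of phenyl on an aromatic carbon moves the number the same way on both cores, so the direction of the change carries from the core of compound 1 to the core of compound 3, with an at least 13-fold higher number from compound 3 to compound 4 (1.14 log units; beyond the scatter) as the new step. This rests on two instances at differently placed positions, and the size of the change is not shown to carry over or to differ: the same change on two cores in this assay, a 5.6-fold higher number (0.74 log units; beyond the scatter) from compound 1 to compound 2 and an at least 13-fold higher number (1.14 log units; beyond the scatter) from compound 3 to compound 4; the limit leaves it open whether they differ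

The compounds shown leave open whether a methyl, a methoxy or a pyridyl group in place of the phenyl, para to a large group, would keep the number near that of compound 3 at 720 nM. They also leave open what an amine or a carboxylic acid at that place would do, and how far compound 4 lies past its limit.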